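The compounds below may be only part of what the source reports. "The series", "measured", "known", "first", "only" and "open" are said of these compounds alone.

Three compounds built on a shared core have been examined in an ADME assay on microsomes from liver (Rattus norvegicus) for metabolic stability, read by LC-MS, with a stated time of 30 min, tested at 1 uM; a higher number here means that more of the compound is left, a lower number that less of the compound is left. Compound 1 `CCNCc1cc(Cl)cc(Nc2nc3ccccc3n2Cc2ccc(C(F)(F)F)cc2)c1O` carries a 4-(trifluoromethyl)benzyl group on an aromatic nitrogen of its core, and in this assay compound 1 gives 66%. Compound 3 `CCNCc1cc(Cl)cc(Nc2nc3cc(F)c(F)cc3n2Cc2ccc(C(F)(F)F)cc2)c1O` carries the same group on a core that differs from that of compound 1; how the two cores differ is not broken down here. In this assay compound 3 gives 98%, which stands a number at least 1 percentage points higher from compound 3 to compound 2 (that floor lies within the scatter). Compound 2 `CCNCc1cc(Cl)cc(Nc2nc3cc(F)c(F)cc3[nH]2)c1O` is compound 3 with hydrogen in place of 4-(trifluoromethyl)benzyl on an aromatic nitrogen. The result for compound 2 in this assay is a limit of the method rather than a number, reported as > 99%. That reading reflects (the limit of > 99% in this assay, at which 1 of the 3 values shown sits), so the true size of the step from compound 3 to compound 2 cannot be pinned down beyond its floor.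

Compound 4 `CCNCc1cc(Cl)cc(Nc2nc3ccccc3[nH]2)c1O` has not yet been measured. Compared with compound 1 it shows (hydrogen in place of 4-(trifluoromethyl)benzyl on an aromatic nitrogen), the same change that turns compound 3 into compound 2. Because compound 3 moved by a number at least 1 percentage points higher from compound 3 to compound 2 (that floor lies within the scatter), the matching change on compound 1 is expected to raise the share of compound remaining as well, and the lower starting point of compound 1 at 66% leaves more room for it to rise. On that basis the step from compound 1 to compound 4 is estimated at a number 22 percentage points higher from compound 1 to compound 4 (beyond the scatter). For compound 4 in this assay the expected result is 88%, with an estimated range from 70% to 99%.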

Compound 4, percent of the compound remaining: 98%
Beside the measured number, compound 4's estimate is 10 percentage points below it; measured number inside the range.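

In this assay, putting hydrogen in place of 4-(trifluoromethyl)benzyl on the aromatic nitrogen gives a number 32 percentage points higher from compound 1 to compound 4 (beyond the scatter), a large step, so on the core of compound 1 this single change goes with much more of the compound being left. This does not show that the change carries over to another core with the same size, and the step on the core of compound 3 cannot settle this: the same change on two cores in this assay, a number at least 1 percentage points higher (that floor lies within the scatter) from compound 3 to compound 2 and a number 32 percentage points higher (beyond the scatter) from compound 1 to compound 4; the limit leaves it open whether they differ. What keeps that comparison open is a reading at the end of the measurable range, not a number: the limit of > 99% in this assay, at which 1 of the 4 values shown sits.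

The compounds shown carry only hydrogen or 4-(trifluoromethyl)benzyl on this aromatic nitrogen, so it stays open how a small methyl group, a plain benzyl group without the trifluoromethyl, or a longer chain ending in an amine or a carboxylic acid would read in this assay. On these data alone, it also stays open whether the large step on the core of compound 1 belongs to the whole 4-(trifluoromethyl)benzyl group or only to one part of it, and whether intermediate groups would give intermediate results.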